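This account rests on a few compounds, and the source may have more. Where it says the series, first, only, none or still open, it means among the compounds named here.

Measured compounds:
- compound 1 `CC1CCN(c2c(S(=O)(=O)c3ccc(Cl)cc3)cnc3cc(Cl)ccc23)CC1`: an assay on isolated protein for displacement of a labelled ligand from metabotropic glutamate receptor 5 (Homo sapiens), with a stated time of 60 min, tested at 1 uM (on this read-out higher numbers stand for more inhibition at the one concentration tested (going by the name of the read-out) and lower numbers for less inhibition), 91%
- compound 2 `CC1CCN(c2c(S(=O)(=O)c3ccc(Cl)cc3)cnc3cc(F)ccc23)CC1`: 90%
- compound 3 `COc1cccc(S(=O)(=O)c2cnc3ccc(F)cc3c2N2CCC(C)CC2)c1`: 90%

Compound 2 stands level with compound 3 at the digits shown, the two together being the lowest of the three numbers; the gap to compound 1 is within the scatter. Within the data shown here, the only step between compounds differing in one place is a number 1 percentage points lower from compound 1 to compound 2 (within the scatter), fluoro in place of chloro on an aromatic carbon, and it lies within the scatter.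

Compound 4 `Cc1ccc(S(=O)(=O)c2cnc3cc(F)ccc3c2N2CCC(C)CC2)cc1C` differs from compound 2 by 3,4-dimethylphenyl in place of 4-chlorophenyl on a sulfonyl sulfur. Among the measured compounds shown here, no measured step touches the aryl on the sulfonyl sulfur. Compound 3 carries a different aryl there and still gives a number level with compound 2, though it differs at a second place too. On this basis no step beyond the scatter is expected, a number 4 percentage points lower from compound 2 to compound 4 (within the scatter). Compound 4 is estimated at 86%, range 66% to 97%.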

Compound 4, a percentage reported as inhibition, at one concentration (the size of the read-out at that concentration, not a potency): 90%
Beside the measured number, compound 4's estimate is 4 percentage points below it; the range from low to high includes it.
By their numbers in this assay, from the lowest: compounds 2, 3, 4 and 1 (each within the scatter of the next).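

In this assay, 3,4-dimethylphenyl in place of 4-chlorophenyl on a sulfonyl sulfur gives no change at the digits printed from compound 2 to compound 4 (within the scatter). Among these compounds, this is the first single-place step read at this position, and it shows that the aryl there can lose its chlorine and gain an all-carbon substitution without a step beyond the scatter. No measurement shown bears on the reason for this result. Still open, from the compounds shown here alone, is how a carboxylic acid or an amine on this aryl would read. Also open, going by these compounds, is whether compounds that read alike at this one concentration also match in potency.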